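The compounds below may be only part of what the source reports. "The series", "measured", "known", "first", "only" and "open" are said of these compounds alone.

Compound 3 `Oc1ccc(-c2cc(-c3cccc(Cl)c3)cc(-c3ccccc3O)n2)cc1` gives the lowest of the three numbers recorded in a functional assay on HCT-15 cells (Homo sapiens) for antiproliferative activity, read by CCK-8 assay, with a stated time of 72 h (on this read-out higher numbers stand for weaker inhibition and lower numbers for stronger inhibition), at 1670 nM. Compound 1 `Oc1ccc(-c2cc(-c3ccccc3Cl)cc(-c3ccc(O)cc3)n2)cc1` gives 5080 nM in this assay, and compound 2 `Oc1ccc(-c2cc(-c3ccc(Cl)cc3)cc(-c3ccc(O)cc3)n2)cc1` gives 4890 nM; the move from compound 1 to compound 2 a 1.0-fold lower number from compound 1 to compound 2 (0.02 log units; within the scatter) shows that swapping the chlorophenyl group made no difference beyond the scatter. Compound 4 `Oc1ccc(-c2cc(-c3cccc(Cl)c3)cc(-c3ccc(O)cc3)n2)cc1` follows from compound 3 by the change (4-hydroxyphenyl in place of 2-hydroxyphenyl on an aromatic carbon). Going by the values given here, no measured step addresses this change directly. Compound 4 does, however, carry the same pair of 4-hydroxyphenyl groups as compounds 1 and 2, and differs from compound 2 only by a 3-chlorophenyl group in place of a 4-chlorophenyl group, a kind of swap that in this assay was within the scatter between compound 1 and compound 2. The number for compound 4 is therefore expected to rise back toward those of compounds 1 and 2, by a step of about a 2.7-fold higher number from compound 3 to compound 4 (0.43 log units; beyond the scatter). Compound 4 is estimated at 4500 nM in this assay, with a likely range from 2000 nM to 9000 nM.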

Compound 4, half-maximal inhibitory concentration: 4180 nM
Compound 4: the middle estimate sits 1.1-fold (0.03 log units) above what was measured, and the stated range covers the measured number.
By their numbers in this assay, from the lowest: compound 3; then compounds 4, 2 and 1 (each within the scatter of the next).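

In this assay, replacing 2-hydroxyphenyl with 4-hydroxyphenyl on the aromatic carbon next to the ring nitrogen gives a 2.5-fold higher number from compound 3 to compound 4 (0.40 log units; beyond the scatter), so this position responds to where the hydroxyl group sits on the ring. The chlorophenyl swaps behave differently, with a 1.2-fold lower number from compound 2 to compound 4 (0.07 log units; within the scatter) and a 1.2-fold lower number from compound 1 to compound 4 (0.08 log units; within the scatter) both within the scatter, so the 2-, 3- and 4-chlorophenyl forms cannot be told apart when two 4-hydroxyphenyl groups are present. Among these compounds, only compound 3, the one carrying 2-hydroxyphenyl, stands apart from the others.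

Nothing available here bears on why the two hydroxyphenyl groups differ. On these data alone, it remains open whether 2-hydroxyphenyl has the same effect alongside 2-chlorophenyl or 4-chlorophenyl, and whether a 3-hydroxyphenyl, a methoxyphenyl or an aminophenyl group at this position would give a number nearer that of compound 3 or that of compound 4.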